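Trading an ester for a ketone along the same chain

The source may hold more compounds than are shown below. What is called first, only, known or untested is meant among the compounds shown, and "the series" means these compounds.

Of the compounds shown here, two have been measured in a physicochemical assay for lipophilicity; a lower number here means a more polar compound, a higher number a more lipophilic compound. Compound 1 `CC(/C=C/CC(C)CCCC(C)C)=C\C(=O)OC(C)C` gives 7.15. Compound 2 `C#CCCOC(=O)/C=C(C)/C=C/CC(C)CCCC(C)(C)OC` gives 5.2, the lower of the two numbers, and the gap between compound 2 and compound 1 is beyond the usual scatter. The next compound, compound 3 `COC(C)(C)CCCC(C)C/C=C/C(C)=C/C(=O)CC(C)C`, has not been measured yet. It differs from compound 2 in one place: isobutyl in place of (but-3-yn-1-yl)oxy on a carbonyl carbon. An ester with a triple-bonded chain thus becomes a ketone with a simple branched chain, and one hydrogen-bond acceptor goes away. Such a change is expected to move the number in this assay upward by a modest amount, more than the scatter but well short of the gap seen between compound 2 and compound 1; the expected step is a number 0.80 log units higher from compound 2 to compound 3 (beyond the scatter). Compound 3 is therefore estimated at 6, with a likely range from 5.5 to 6.6.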

Compound 3, partition coefficient: 6.02
Compound 3: the middle estimate sits 0.02 log units below what was measured, and the stated range covers the measured number.
By their numbers in this assay, from the lowest: compound 2; then compound 3; then compound 1.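

On a carbonyl carbon whose other neighbour is a double-bonded chain carbon, putting isobutyl in place of (but-3-yn-1-yl)oxy gives a number 0.82 log units higher from compound 2 to compound 3 (beyond the scatter) in this assay, so a change at this one place registers in the read-out. Among the compounds shown here, this is the first pair here that differs in one place only, which makes it the first step that can be tied to a single swap. The group that leaves carries both an oxygen and a triple bond while the group that enters carries neither, and nothing at hand accounts for the step.

Still open, on these data alone, is how much of the step goes with the oxygen and how much with the triple bond. A butoxy group on the same carbonyl carbon would separate the two, and an amine there, giving an amide, would test a different kind of carbonyl group.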